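Ethyl to propyl on an essentially inactive series

The compounds below may be only part of what the source reports. "The series", "measured", "known", "first", "only" and "open" are said of these compounds alone.

Measured compounds:
compound 1 `COCc1nc(C)c2c(C)nnc(O)n12`; in a functional assay for inhibition, with Homo sapiens as the target (on this read-out lower numbers stand for stronger inhibition and higher numbers for weaker inhibition), compound 1 reaches only a limit of the assay, > 48000 nM.
compound 2 `C=CCn1ncc2c(C)nc(CC)n2c1=O`; in this assay compound 2 reaches only a limit of the assay, > 48000 nM.
compound 3 `CCc1nc(C)c2cnn(CC)c(=O)n12`; in this assay compound 3 gives 75600 nM.

Compound 2 thus stands at a limit, not at a number, and two of the three values shown sit at that same limit (the limit of > 48000 nM in this assay, at which 2 of the 3 values shown sit). Among the measured compounds shown here, compound 3 is the only compound with a read number, and it is weak.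

Compound 4 `C=CCn1ncc2c(C)nc(CCC)n2c1=O` differs from compound 2 by methyl in place of hydrogen on a saturated chain carbon, two bonds along the chain from an aromatic carbon; read one bond further out, ethyl becomes propyl.

For the measured compounds named here, the only measured step that touches compound 2 is a step that the limit leaves unreadable from compound 2 to compound 3, and the limit leaves its size unreadable; it concerns the chain on the aromatic nitrogen, not the chain being lengthened here. Going by the values given here, no measured step bears on the ethyl to propyl change at all. Nothing in the data therefore supports expecting a readable step in this assay in either direction.

The step expected from compound 2 to compound 4 is a step that the limit leaves unreadable from compound 2 to compound 4, most likely again unreadable. Compound 4 is estimated at 60000 nM, in the range 20000 nM to 200000 nM, with a high chance of another limit.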

Compound 4, half-maximal inhibitory concentration: 40000 nM
Estimate against measurement, compound 4: 1.5-fold (0.18 log units) above; the measured number falls inside the stated range.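

In this assay, among the compounds shown here, the change from ethyl to propyl gives an at least 1.2-fold lower number from compound 2 to compound 4 (0.07 log units; that floor lies within the scatter) and so places a read number at a position where the earlier compounds offered no readable step. Adding one methyl two bonds along the chain from an aromatic carbon leaves compound 4 within the measurable range of the assay, yet no gain beyond the scatter can be claimed, and the compound remains weak. The true size of the step stays unknown because compound 2 stands at a limit rather than at a number: the limit of > 48000 nM in this assay, at which 2 of the 4 values shown sit.

From the compounds shown here alone, whether a butyl group or a longer chain at this place would move the number beyond the scatter remains open, as does the effect of an amine or a carboxylic acid at the end of the chain. Also open, going by these compounds, is whether the same lengthening would read differently with the ethyl on the aromatic nitrogen seen in compound 3, since the step that links that chain to compound 2 cannot be read.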